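The compounds below may be only part of what the source reports. "The series", "measured", "known", "first", "only" and "open" are said of these compounds alone.

In an ADME assay on MT4 cells (Homo sapiens) for cytotoxicity, read by MTT assay, with a stated time of 5 days (a lower number here means that less compound is tolerated, a higher number that more compound is tolerated), compound 1 `COc1cc2nc(SCC(=O)Nc3cc([N+](=O)[O-])ccc3F)nc(Nc3c(Cl)cc(/C=C/C#N)cc3Cl)c2cc1OC` gives > 199000 nM as a limit of the assay and not a number. Two further compounds do give numbers. Compound 2 `COc1cc2nc([S+]([O-])CC(=O)Nc3ccc([N+](=O)[O-])cc3)nc(Nc3c(C)cc(/C=C/C#N)cc3C)c2cc1OC` reads 189000 nM in this assay and compound 3 `COc1cc2nc([S+]([O-])CC(=O)Nc3ccc([N+](=O)[O-])cc3)nc(Nc3c(Cl)cc(/C=C/C#N)cc3Cl)c2cc1OC` reads 92800 nM here, so compound 3 holds the lower of the two numbers and is the less well tolerated of this pair.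

The next compound to be tested is compound 4 `COc1cc2nc([S+]([O-])CC(=O)Nc3ccccc3F)nc(Nc3c(Cl)cc(/C=C/C#N)cc3Cl)c2cc1OC`. It carries 2-fluorophenyl in place of 4-nitrophenyl on an amide-type nitrogen, and the counted difference is 2-fluorophenyl in place of 4-nitrophenyl on an amide-type nitrogen.

Among the compounds with values here, no measured step makes this exchange. Within the data shown here, the only step available is a 2.0-fold lower number from compound 2 to compound 3 (0.31 log units; beyond the scatter), which is modest and lies on a nitrogen on an aromatic ring, a different place from the amide-type nitrogen. It therefore bears on the new change only as a rough guide to how far a single exchange can move a number in this series. With so little to go on, no clear direction can be argued, and no shift beyond the scatter is expected. The expected step is a 1.1-fold higher number from compound 3 to compound 4 (0.03 log units; within the scatter) without a firm direction. For compound 4 the estimated value is 100000 nM, with an expected range from 45000 nM to 200000 nM.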

Compound 4, half-maximal cytotoxic concentration: > 208000 nM
Compound 4: a limit, no number; the forecaster's own chance of this, stated with the estimate: 20%; at least 2.0-fold (0.31 log units) between middle value and limit.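

Among the earlier compounds, the only measured step lay on a nitrogen on an aromatic ring, so nothing yet showed what the amide-type nitrogen contributes. In this assay, putting 2-fluorophenyl in place of 4-nitrophenyl on that nitrogen gives an at least 2.2-fold higher number from compound 3 to compound 4 (0.35 log units; beyond the scatter), so the group carried there can move this reading beyond the usual scatter, and here the move is towards more compound being tolerated. The reading for compound 4 is a limit of the assay and not a number, which fixes the direction of the step but leaves its full size unknown: the limit of > 208000 nM in this assay, at which 1 of the 4 values shown sits.

This single exchange removes the nitro group, adds a fluorine and changes where the ring carries its substituent, all at once, so the compounds shown cannot tell which of these goes with the higher number. On these data alone, a plain phenyl group or an aminophenyl group on the same amide-type nitrogen would help to separate these parts, and whether the shift holds with other groups on the rest of the molecule also stays open.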